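The source may hold more compounds than are shown below. What is called first, only, known or untested is meant among the compounds shown, and "the series" means these compounds.

Among the two compounds measured in a functional assay on ileum (strain Hartley) for agonist activity at 5-hydroxytryptamine receptor 3A (Cavia porcellus) (on this read-out lower numbers stand for lower potency and higher numbers for higher potency (the scale is a negative logarithm)), compound 2 `CN1CCN(c2nc3cccc(Cl)c3o2)CC1` gives 5.5, the lower of the two numbers, while compound 1 `COc1cc(Cl)cc2nc(N3CCN(C)CC3)oc12` gives 6.16 in this assay, a gap beyond the usual scatter. Compound 3 `COc1cccc2nc(N3CCN(C)CC3)oc12` carries methoxy in place of chloro on an aromatic carbon, and the same methoxy appears in compound 1. Because compound 1 reaches 6.16, the step from compound 2 to compound 3 is expected to be upward and moderate, about a number 0.40 log units higher from compound 2 to compound 3 (beyond the scatter). For compound 3 the estimate in this assay is 5.9, with a range from 5.3 to 6.5.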

Compound 3, negative logarithm of the half-maximal effective concentration: < 4
Compound 3: only a limit was reported; the forecaster's own chance of this, stated with the estimate: 5%; middle value at least 1.90 log units from the limit.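

Compound 3 carries only a limit in this assay: the limit of < 4 in this assay, at which 1 of the 3 values shown sits. Methoxy in place of chloro on this aromatic carbon gives a number at least 1.50 log units lower from compound 2 to compound 3 (beyond the scatter), so methoxy here does not keep the activity of compound 2. Hydrogen in place of chloro on a different aromatic carbon gives a number at least 2.16 log units lower from compound 1 to compound 3 (beyond the scatter), so the methoxy of compound 1 gives no measurable number in this assay without that chloro. The compounds shown leave open how a methyl or an amine would behave on the carbon that carries chloro in compound 2.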